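A few compounds are considered here, and "the series" means these few. Any claim that something is new, unique, unknown or untested is made for them only; others in the source may bear on it.

In a functional assay on CCRF-CEM cells (Homo sapiens) for cytotoxicity, read by MTT assay, with a stated time of 72 h (a higher number here means that more compound is tolerated, a lower number that less compound is tolerated), compound 3 `CCCCC[Se]c1nc(NCc2ccccc2)c2ccccc2n1` gives > 100000 nM, which is a limit of the assay rather than a measured number. Compound 2 `Sc1nc(NCc2ccccc2)c2ccccc2n1` gives > 100000 nM, also a limit. The step that the two limits leave unreadable from compound 2 to compound 3 is therefore not readable. Compound 1 `CSc1ccc(CNc2nc([SeH])nc3ccccc23)cc1` gives > 100000 nM, again a limit. For the measured compounds named here, all three measured values sit at the limit of > 100000 nM in this assay, at which 3 of the 3 values shown sit, so no step in this small set can be sized at all.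

Compound 4 `[SeH]c1nc(NCc2ccccc2)c2ccccc2n1` differs from compound 3 in one place: hydrogen in place of pentyl on a selenium. Going by the values given here, the only measured step is unreadable, so no measured step bears on this change, and the three measured compounds, whatever their groups on sulfur or selenium, all stay at the limit. Compound 4 is therefore expected to stay at the limit as well, and the estimated step that the limit leaves unreadable from compound 3 to compound 4 is expected to be nothing beyond the scatter. For compound 4 the estimate in this assay is 150000 nM, with a range from 60000 nM to 500000 nM.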

Compound 4, concentration lethal to 50% of the cells: > 100000 nM
Compound 4: a limit, no number (the forecaster's own chance of this, stated with the estimate: 80%); the middle value lies beyond the limit too.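

No new step can be read from compound 1, compound 2 or compound 3 to compound 4 in this assay, since each value is a limit rather than a number: the limit of > 100000 nM in this assay, at which 4 of the 4 values shown sit.

The compounds shown leave open how far each lies beyond that limit, and so whether any of these changes alters the tolerated concentration.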